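Indole-amine series: removing the acetyl of compound 3

The compounds below may be only part of what the source reports. "The series", "measured", "known", "first", "only" and "open" are said of these compounds alone.

Measured so far:
compound 1 `Fc1cccc(CNCc2c[nH]c3ccccc23)c1F` -1.7%
compound 2 `O=C(N(Cc1cccc(F)c1F)Cc1cn(S(=O)(=O)c2ccc(F)cc2)c2ccccc12)C(F)(F)F` -52.3%
compound 3 `CC(=O)N(Cc1cccc(F)c1F)Cc1cn(S(=O)(=O)c2ccc(F)cc2)c2ccccc12` 25.8%

In a functional assay on 3T3-L1 cells (Mus musculus) for inhibition, with a stated time of 20 min, tested at 20 uM (a higher number here means more inhibition at the concentration tested (going by the name of the read-out), a lower number less inhibition), compound 3 stands highest of the three numbers; compound 1 sits nearest, and compound 2 furthest, both beyond the scatter. For the measured compounds named here, the one step that joins two measured compounds is a number 78.1 percentage points higher from compound 2 to compound 3 (beyond the scatter), a large move for a change at the carbonyl carbon alone.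

Compound 4 `O=S(=O)(c1ccc(F)cc1)n1cc(CNCc2cccc(F)c2F)c2ccccc21` is not yet measured. It differs from compound 3 by hydrogen in place of acetyl on an amine nitrogen. Going by the values given here, no measured step removes an acyl group from this amine nitrogen, so the size of the change is not known from the series. Among the compounds with values here, compound 1, the only other compound carrying a hydrogen on that nitrogen, gives -1.7%, but it also lacks the sulfonyl of compound 4, and no step covers that pair. Within the data shown here, what the data show is only that a change at this position can move the read-out a long way, in either direction. For compound 4 the number is therefore expected to fall between the values of compound 1 and compound 3, with a wide range, and the step of a number 17.8 percentage points lower from compound 3 to compound 4 (beyond the scatter) is expected to be modest and downward. The estimate for compound 4 is 8%, from -25% to 35%.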

Compound 4, a percentage reported as inhibition, at one concentration (the size of the read-out at that concentration, not a potency): 21%
Beside the measured number, compound 4's estimate is 13 percentage points below it, and the stated range covers the measured number.
By their numbers in this assay, from the lowest: compound 2; then compound 1; then compounds 4 and 3 (each within the scatter of the next).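

In this assay, hydrogen and acetyl on this amine nitrogen cannot be told apart (a number 4.8 percentage points lower from compound 3 to compound 4 (within the scatter)). The large gap at this position belongs to the (trifluoromethyl)carbonyl group alone (a number 73.3 percentage points higher from compound 2 to compound 4 (beyond the scatter)), so an acyl group on this nitrogen is not in itself what sets the number. The (4-fluorophenyl)sulfonyl on the aromatic nitrogen now has a step of its own, a modest one with hydrogen on the amine nitrogen in both compounds (a number 22.7 percentage points higher from compound 1 to compound 4 (beyond the scatter)), and nothing shown gives a reason for any of these steps.

Open, going by these compounds, is whether other groups on the amine nitrogen, such as a methyl or a propanoyl, would read like hydrogen and acetyl or like the (trifluoromethyl)carbonyl group. Also open, on these data alone, is whether a plain phenylsulfonyl on the aromatic nitrogen would give the same step.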